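This account rests on a few compounds, and the source may have more. Where it says the series, first, only, none or still open, it means among the compounds named here.

Measured compounds:
Compound 1 `Cc1cc(=O)n2nc(SCc3ccc(F)cc3)nc2[nH]1`: in a functional assay on A549 cells (Homo sapiens) for antiproliferative activity, read by MTT assay, with a stated time of 24 h (on this read-out higher numbers stand for weaker inhibition and lower numbers for stronger inhibition), compound 1 gives > 80000 nM, which is a limit of the assay and not a number.
Compound 2 `Cc1cc(=O)n2nc(SCc3cccc(C(F)(F)F)c3)nc2[nH]1`: compound 2 gives 72000 nM.
Compound 3 `Cc1ccc(CSc2nc3[nH]c(C)cc(=O)n3n2)cc1`: compound 3 gives 50100 nM.

Compound 1 stands only as a limit on this read-out (the limit of > 80000 nM in this assay, at which 1 of the 3 values shown sits), so its true number is not known. Compound 4 `Cc1cc(=O)n2nc(SCc3ccc([N+](=O)[O-])cc3)nc2[nH]1` differs from compound 1 by nitro in place of fluoro on an aromatic carbon. Among the measured compounds shown here, the one measured step at the same place is an at least 1.5-fold lower number from compound 1 to compound 3 (0.20 log units; that floor lies within the scatter), a change that does not clear the scatter. For the measured compounds named here, no measured step involves a nitro group, so the step from compound 1 to compound 4 is expected to be small and uncertain, with the result quite possibly another limit. Compound 4 is estimated at 65000 nM (range 25000 nM to 150000 nM), which means an expected step of an at least 1.2-fold lower number from compound 1 to compound 4 (0.09 log units; that floor lies within the scatter).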

Compound 4, half-maximal inhibitory concentration: > 80000 nM
Compound 4: only a limit was reported; the forecaster's own chance of this, stated with the estimate: 40%; middle value at least 1.2-fold (0.09 log units) from the limit.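

In this assay compound 4 gives > 80000 nM, which is a limit of the assay and not a number. Compound 1 also stands as a limit, so the step between these two cannot be read, and neither fluoro nor nitro at this place gives a measurable number: the limit of > 80000 nM in this assay, at which 2 of the 4 values shown sit. Among the compounds shown here, the only readable step is an at least 1.5-fold higher number from compound 3 to compound 4 (0.20 log units; that floor lies within the scatter), so nitro in place of methyl shows no change that clearly clears the scatter.

As far as these compounds go, how far the true numbers of compound 1 and compound 4 lie past the limit remains unknown. From the compounds shown here alone, whether an amine or a carboxylic acid at this place would give a measurable number also remains open.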